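Replacing the piperazine linker by a direct cyclohexyl group

The source may hold more compounds than are shown below. What is called first, only, known or untested is meant among the compounds shown, and "the series" means these compounds.

Compound 1 `CC(C(=O)NCc1ccc(C(F)(F)F)cc1N1CCN(C2CCCCC2)CC1)c1ccc(NS(C)(=O)=O)c(F)c1`: 13.8 nM
Compound 2 `CC(C)CCSc1cc(C(F)(F)F)ccc1CNC(=O)C(C)c1ccc(NS(C)(=O)=O)c(F)c1`: 1.4 nM
Compound 3 `CC(C(=O)NCc1ccc(C(F)(F)F)cc1SCCCO)c1ccc(NS(C)(=O)=O)c(F)c1`: "not active" (no number reported)

All three measured compounds share one core and differ only in the group carried on the aromatic carbon that sits meta to the trifluoromethyl group. Among the compounds with values here, in an assay on CHO cells for antagonist activity at transient receptor potential cation channel subfamily V member 1 (Homo sapiens), read by FLIPR (a lower number here means a stronger inhibitor, a higher number a weaker inhibitor), compound 1 gives 13.8 nM, the highest of the two numbers reported; the nearest entry is compound 2, and the one change that separates them, isopentylsulfanyl in place of 4-cyclohexylpiperazin-1-yl on an aromatic carbon, gives a 9.9-fold lower number from compound 1 to compound 2 (0.99 log units; beyond the scatter). Compound 3 carries a different sulfanyl chain at the same place and is reported as "not active" (no number reported), with no single number given.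

Compound 4 `CC(C(=O)NCc1ccc(C(F)(F)F)cc1C1CCCCC1)c1ccc(NS(C)(=O)=O)c(F)c1` has not yet been measured. It differs from compound 1 as follows: cyclohexyl in place of 4-cyclohexylpiperazin-1-yl on an aromatic carbon. Within the data shown here, the only step that bears on this change is the one from compound 1 to compound 2, which was modest in size and ran toward a lower number, and compound 4, like compound 2, keeps a ring of carbon only at this position while dropping the ring with two hetero atoms. A step of similar direction is therefore expected for compound 4, estimated as a 4.6-fold lower number from compound 1 to compound 4 (0.66 log units; beyond the scatter). Compound 4 is expected to give about 3 nM in this assay, within a range of 0.8 nM to 12 nM.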

Compound 4, inhibition constant: 0.6 nM
Beside the measured number, compound 4's estimate is 5.0-fold (0.70 log units) above it, and the stated range ends above it.
By their numbers in this assay, from the lowest: compound 4; then compound 2; then compound 1.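

In this assay, the piperazine ring with two hetero atoms can be removed from this aromatic carbon, leaving the cyclohexyl attached directly, with a gain rather than a loss (a 23-fold lower number from compound 1 to compound 4 (1.36 log units; beyond the scatter)). The group at this place falls from 12 heavy atoms to 6, so the full 4-cyclohexylpiperazin-1-yl group is not needed for a low number among these compounds. The cyclohexyl also surpasses the isopentylsulfanyl chain, the best group known until now (a 2.3-fold lower number from compound 2 to compound 4 (0.37 log units; beyond the scatter)), which gives compound 4 the lowest number of the three compounds with values, although nothing presented here accounts for either step.

Steps involving compound 3 cannot be read, as it has no single number, so how its sulfanyl chain compares with the cyclohexyl remains unquantified. Going by these compounds, it also remains open whether a cyclopentyl, a phenyl or a piperidine ring on this carbon would keep the number as low, and whether an amine on the cyclohexyl would be tolerated.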